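The compounds below may be only part of what the source reports. "The series", "measured", "known", "first", "only" and "open" are said of these compounds alone.

Measured compounds:
compound 1, `COc1cc(-c2cc(/C=C/C(=O)c3ccc(N)cc3)[nH]n2)cc(OC)c1OC`, with 9810 nM;
compound 2, `COc1ccc(C(=O)/C=C/c2cc(-c3cc(OC)c(OC)c(OC)c3)n[nH]2)cc1OC`, with 825 nM;
compound 3, `COc1ccc(C(=O)/C=C/c2cc(-c3cc(OC)c(OC)c(OC)c3)n[nH]2)cc1`, with 6970 nM.

All three were tested in a functional assay on NCI-H522 cells (Homo sapiens) for inhibition, read by sulforhodamine B assay, with a stated time of 48 h; on this read-out higher numbers stand for lower toxicity in this test and lower numbers for higher toxicity in this test. The three compounds share one core; compound 1 and compound 2 differ by 4-aminophenyl in place of 3,4-dimethoxyphenyl on a carbonyl carbon, and this gives a 12-fold lower number from compound 1 to compound 2 (1.08 log units; beyond the scatter). Compound 1 and compound 3 show a 1.4-fold lower number from compound 1 to compound 3 (0.15 log units; within the scatter). Compound 2 and compound 3 differ by hydrogen in place of methoxy on an aromatic carbon, and that change gives an 8.4-fold higher number from compound 2 to compound 3 (0.93 log units; beyond the scatter).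

Compound 4, `COc1ccc(-c2cc(/C=C/C(=O)c3ccc(N)cc3)[nH]n2)cc1OC`, has not yet been tested. Compared with compound 1 it shows (hydrogen in place of methoxy on an aromatic carbon). This is the same kind of change as from compound 2 to compound 3, but the place is not the same: in compound 4 the carbon that loses its methoxy is also meta to a methoxy group, which the place in compound 3 is not. Because the earlier change gave an 8.4-fold higher number from compound 2 to compound 3 (0.93 log units; beyond the scatter), a step in the same direction is expected here, though its size is uncertain since the surroundings differ and compound 1 already stands at 9810 nM. In this assay compound 4 is expected to give 22000 nM, with a range from 8000 nM to 60000 nM. The expected step is a 2.2-fold higher number from compound 1 to compound 4 (0.35 log units; beyond the scatter).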

Compound 4, concentration lethal to 50% of the cells: 6300 nM
The estimate for compound 4 lay 3.5-fold (0.54 log units) above the measured number; the whole stated range lies above it.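

On the core of compound 1, hydrogen in place of methoxy gives a 1.6-fold lower number from compound 1 to compound 4 (0.19 log units; within the scatter), so this step cannot be told apart from the ordinary spread of repeated measurements. Among these compounds, the same kind of change had a clear effect on the other core, and the two results in this assay do not agree: the same change on two cores in this assay, an 8.4-fold higher number (0.93 log units; beyond the scatter) from compound 2 to compound 3 and a 1.6-fold lower number (0.19 log units; within the scatter) from compound 1 to compound 4, 13-fold (1.12 log units) apart, beyond the scatter of two such steps This shows that the step seen on one core cannot simply be carried over as a fixed amount to the other, but with only two pairs it does not show what makes them differ, since the methoxy group leaves from a different place in each pair and the rest of the molecule differs as well.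

The compounds shown leave open whether a hydroxyl group, a fluorine atom or an ethoxy group in place of that methoxy would behave any differently on either core. They also leave open how the change would behave on further cores, so a third pair would be needed before any rule could be drawn.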